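Rearranging the Carbamoyl Group in a Tripeptide-like Series Tested on Trypsin

The compounds below may be only part of what the source reports. "The series", "measured", "known", "first", "only" and "open" are said of these compounds alone.

Compound 1 `C[C@](NC(=O)[C@H](CCCCN)NC(=O)[C@H](CCCNC(=N)N)NC(=O)c1ccccc1)(C(N)=O)c1ccccc1`: compound 1 gives 11.8% in an assay on isolated protein for inhibition of Trypsin (Homo sapiens), read by fluorescence, with a stated time of 15 min, tested at 50 uM; on this read-out lower numbers stand for less inhibition and higher numbers for more inhibition at the one concentration tested (going by the name of the read-out).
Compound 2 `CN(C(=O)[C@H](CCCNC(=N)N)NC(=O)c1ccccc1)[C@@H](CCCCN)C(=O)N[C@@H](C(N)=O)c1ccccc1`: compound 2 gives <= 5% in this assay, which is a limit of the measurement rather than a number.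

For the measured compounds named here, compound 1 holds the only numerical value in this assay, and its inhibition is modest. Compound 2 sits at the limit of <= 5% in this assay, at which 1 of the 2 values shown sits. Going by the values given here, no step between two measured compounds is available for this assay, so no measured size of change can be drawn on.

Compound 3 `N=C(N)NCCC[C@H](NC(=O)c1ccccc1)C(=O)N[C@@H](CCCCN)C(=O)N[C@@H](CC(N)=O)c1ccccc1` is built from the same atoms as compound 1, joined differently: 2-carbamoyl-1-phenylethyl in place of 1-carbamoyl-1-phenylethyl on an amide-type nitrogen. The carbamoyl group thereby moves one carbon further along the chain while the phenyl stays in place. Given the inhibition of compound 1 at 11.8%, compound 3 is expected to give a number at a level similar to that of compound 1 in this assay. Compound 3 is expected to give 10%, with a range from 3% to 20%. The step of a number 1.8 percentage points lower from compound 1 to compound 3 (within the scatter) is expected to stay within the usual scatter, in no clear direction.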

Compound 3, a percentage reported as inhibition, at one concentration (the size of the read-out at that concentration, not a potency): 7.5%
The estimate for compound 3 lay 2.5 percentage points above the measured number; measured number inside the range.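

In this assay, the rearrangement gives a number 4.3 percentage points lower from compound 1 to compound 3 (within the scatter), so on this read-out 2-carbamoyl-1-phenylethyl and 1-carbamoyl-1-phenylethyl cannot be told apart on the amide-type nitrogen. For the compounds shown here, this is the first step that can be read, and it shows that moving the carbamoyl group one carbon along the chain, with the phenyl in place, leaves the inhibition where the scatter cannot separate it from that of compound 1. The data shown offer nothing that accounts for this step.

As far as these compounds go, whether a carboxylic acid or an amine in place of the carbamoyl group, or a longer chain carrying it, would shift the inhibition at this position remains open. The single concentration tested also gives no potency for compound 1 or compound 3.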